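Methoxy Pattern on the Aryl Ring and Cell Inhibition

A few compounds are considered here, and "the series" means these few. Any claim that something is new, unique, unknown or untested is made for them only; others in the source may bear on it.

Compound 1, `COc1ccc(OC)c(-c2cn(-c3ccc(O)c(C(=O)Nc4cccc(C(F)(F)F)c4)c3)nn2)c1`, gives 46% in a functional assay on HCT-116 cells (Homo sapiens) for inhibition, read by MTT assay, with a stated time of 2 days, tested at 10 uM; a higher number here means more inhibition at the concentration tested (going by the name of the read-out), a lower number less inhibition.
Compound 2, `COc1ccc(-c2cn(-c3ccc(O)c(C(=O)Nc4cccc(C(F)(F)F)c4)c3)nn2)cc1`, gives 9%.
Compound 3, `COc1cc(OC)cc(-c2cn(-c3ccc(O)c(C(=O)Nc4cccc(C(F)(F)F)c4)c3)nn2)c1`, gives 62%.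

Compound 3 stands highest of the three: a number 16 percentage points higher from compound 1 to compound 3 (beyond the scatter) and a number 53 percentage points higher from compound 2 to compound 3 (beyond the scatter), both beyond the scatter. Compound 4, `O=C(Nc1cccc(C(F)(F)F)c1)c1cc(-n2cc(-c3cccc(O)c3)nn2)ccc1O`, differs from it in one place: 3-hydroxyphenyl in place of 3,5-dimethoxyphenyl on an aromatic carbon. For the measured compounds named here, no measured pair swaps a methoxy group for a hydroxyl. Going by the values given here, the steps that bear on the change are those altering the methoxy pattern on this ring, a number 53 percentage points higher from compound 2 to compound 3 (beyond the scatter) and a number 16 percentage points higher from compound 1 to compound 3 (beyond the scatter), which show this assay responds strongly to that ring, and the least substituted ring, in compound 2, gave the lowest number. A fall is therefore expected, a number 32 percentage points lower from compound 3 to compound 4 (beyond the scatter). Compound 4 is estimated at 30%, within 5% to 58%.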

Compound 4, a percentage reported as inhibition, at one concentration (the size of the read-out at that concentration, not a potency): 25%
Estimate against measurement, compound 4: 5 percentage points above; the range from low to high includes it.
By their numbers in this assay, from the lowest: compound 2; then compound 4; then compound 1; then compound 3.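

Against the two dimethoxyphenyl rings, the 3-hydroxyphenyl ring loses ground in this assay, with a number 37 percentage points lower from compound 3 to compound 4 (beyond the scatter) and a number 21 percentage points lower from compound 1 to compound 4 (beyond the scatter) in the same assay. Against the 4-methoxyphenyl ring it gains, with a number 16 percentage points higher from compound 2 to compound 4 (beyond the scatter) as the step, so a ring bearing a hydroxyl at this position falls between the methoxy-bearing rings rather than at either end of the series. Nothing measured here explains this order.

The compounds shown leave open whether the fall from compound 3 follows from the hydroxyl itself or from the loss of a methoxy group. As far as these compounds go, how an amine or a carboxylic acid on this ring would read also remains open.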